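From fluoro to isopropoxy: compound 2 and compound 4

A few compounds are considered here, and "the series" means these few. Any claim that something is new, unique, unknown or untested is made for them only; others in the source may bear on it.

Measured in a functional assay on KB cells (Homo sapiens) for antiproliferative activity, read by sulforhodamine B assay, with a stated time of 72 h; a higher number here means a weaker inhibitor, a lower number a stronger inhibitor:
compound 1 `COc1c(OC(C)C)cc2occ(-c3ccccc3)c(=O)c2c1OC(C)C`: > 10000 nM (a limit of the assay, not a number)
compound 2 `O=C(/C=C/c1csc2ccccc12)c1cc(F)ccc1O`: 7400 nM
compound 3 `O=C(/C=C/c1csc2ccccc12)c1cc(Cl)cc(Cl)c1O`: 4600 nM

Compound 1 gives only a limit, > 10000 nM. Compound 3 gives 4600 nM and compound 2 gives 7400 nM, two values within the usual scatter of each other.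

Compound 4 `CC(C)Oc1ccc(O)c(C(=O)/C=C/c2csc3ccccc23)c1` carries isopropoxy in place of fluoro on an aromatic carbon, para to a hydroxy group, compared with compound 2: isopropoxy in place of fluoro on an aromatic carbon. Among the measured compounds shown here, no measured pair shows this change alone, so the expectation rests on compound 2 with its 7400 nM, and no shift beyond the scatter is expected in this assay. The estimated step runs a 1.2-fold lower number from compound 2 to compound 4 (0.09 log units; within the scatter). Compound 4 is expected to give 6000 nM, with an estimated range of 2000 nM to 14000 nM.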

Compound 4, half-maximal inhibitory concentration: 10000 nM
Estimate against measurement, compound 4: 1.7-fold (0.22 log units) below, and the stated range covers the measured number.
By their numbers in this assay, from the lowest: compounds 3, 2 and 4 (each within the scatter of the next, the first and the last beyond it).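

Putting isopropoxy in place of fluoro, para to a hydroxy group, gives a 1.4-fold higher number from compound 2 to compound 4 (0.13 log units; within the scatter) in this assay. So at this position, a branched group with an oxygen atom reads the same as a single fluorine atom, within the usual scatter of the assay. Compound 4 stands at the top of the readable range, where compound 1 gives only a limit: the limit of > 10000 nM in this assay, at which 1 of the 4 values shown sits.

On these data alone, how an amine or a carboxylic acid at this position would read stays open. So does the part played by the hydroxy group itself.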